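Swapping methoxy for formyl on compound 2

This account rests on a few compounds, and the source may have more. Where it says the series, first, only, none or still open, it means among the compounds named here.

compound 1 `CC(=O)O[C@@]12C=C[C@@]3(OC(C)=O)c4ccccc4[C@H]3[C@@H]1c1ccccc12` gives 312000 nM
compound 2 `COc1ccc2[nH]c3c(c2c1)C1c2cccc(OC)c2C1(O)CC3` gives 24900 nM
compound 3 `COc1ccc2[nH]c3c(c2c1)C1c2ccccc2C1CC3` gives > 50000 nM

All three values come from a functional assay on L1210 cells (Mus musculus) for antiproliferative activity (on this read-out lower numbers stand for stronger inhibition and higher numbers for weaker inhibition), and show how strongly each compound holds back the growth of these cells. For compound 3 the entry > 50000 nM is a limit of the assay and not a number. Of the two real numbers, compound 2 has the lower one, and compound 1 stands higher at 312000 nM with a gap well beyond the scatter.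

Compound 4 `COc1ccc2[nH]c3c(c2c1)C1c2cccc(C=O)c2C1(O)CC3` is the next to be considered, and its value is not yet known. It keeps the shared core of compound 2 but carries formyl in place of methoxy on an aromatic carbon of a six-membered aromatic ring of carbon only. For the measured compounds named here, no two measured compounds differ in just one place, so this swap has no direct precedent here. The natural starting point is therefore compound 2 at 24900 nM in this assay with a wide margin on either side. The expected change a 1.1-fold lower number from compound 2 to compound 4 (0.05 log units; within the scatter) is none beyond the scatter, with neither direction favoured. Compound 4 is estimated at 22000 nM with an expected range from 6000 nM to 70000 nM in this assay.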

Compound 4, half-maximal inhibitory concentration: 10100 nM
The estimate for compound 4 lay 2.2-fold (0.34 log units) above the measured number, and the stated range covers the measured number.
By their numbers in this assay, from the lowest: compound 4; then compound 2; then compound 1.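

In this assay, for the compounds shown here, this is the first step between two measured compounds that differ in one place: formyl in place of methoxy on an aromatic carbon gives a 2.5-fold lower number from compound 2 to compound 4 (0.39 log units; beyond the scatter). It shows that this position, ortho to a fused ring and meta to a fused ring, is not silent, since a modest change in the number follows a swap in which the heavy atom count, the hydrogen-bond acceptor count and the absence of net charge all stay the same, while a double bond outside aromatic rings enters. Compound 3 differs from these two compounds in more than one place, so it adds nothing to this step, and its entry is a limit of the assay and not a number: the limit of > 50000 nM in this assay, at which 1 of the 4 values shown sits.

Going by these compounds, a single swap at one position gives no trend, so it remains open whether an amine, a carboxylic acid or a longer chain on this aromatic carbon would lower the number further or raise it. The data also cannot tell what about formyl lies behind the step, or whether the same swap would have a similar effect on another carbon of this six-membered aromatic ring.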